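Two Anilide Ring Swaps, All at the Assay Ceiling

This account rests on a few compounds, and the source may have more. Where it says the series, first, only, none or still open, it means among the compounds named here.

Compound 1 `COc1ccc(NC(=O)c2cccc(/C=C3\CC(=O)N(c4ccccc4)C3=O)c2)cc1`: > 100000 nM (a limit)
Compound 2 `O=C(Nc1cccc(F)c1)c1cccc(/C=C2\CC(=O)N(c3ccccc3)C2=O)c1`: > 100000 nM (a limit)
Compound 3 `CCCCCN1C(=O)C/C(=C\c2cccc(C(=O)Nc3ccc(OC)cc3)c2)C1=O`: > 100000 nM (a limit)

In an ADME assay on SW480 cells (Homo sapiens) for cytotoxicity, read by MTT assay, with a stated time of 72 h (a higher number here means a weaker inhibitor, a lower number a stronger inhibitor), compound 1 gives > 100000 nM, which is a limit of the assay and not a number. Compound 2 gives > 100000 nM, also a limit. Compound 3 gives > 100000 nM, again a limit. From compound 1 to compound 2 the change is 3-fluorophenyl in place of 4-methoxyphenyl on an amide-type nitrogen, and its step that the two limits leave unreadable from compound 1 to compound 2 cannot be sized, because of the limit of > 100000 nM in this assay, at which 3 of the 3 values shown sit. The two cores differ by pentyl in place of phenyl on an amide-type nitrogen in a ring, with step that the two limits leave unreadable from compound 1 to compound 3. Compound 4 `CCCCCN1C(=O)C/C(=C\c2cccc(C(=O)Nc3cccc(F)c3)c2)C1=O` carries the same change, (3-fluorophenyl in place of 4-methoxyphenyl on an amide-type nitrogen). The step expected is a step that the limit leaves unreadable from compound 3 to compound 4, beside the earlier unreadable one, resting on compound 2 sitting at the limit (the limit of > 100000 nM in this assay, at which 3 of the 3 values shown sit). Compound 4 is therefore expected to give about 150000 nM, most likely between 60000 nM and 500000 nM, and most probably as another limit.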

Compound 4, half-maximal inhibitory concentration: > 100000 nM
Compound 4 ended at the assay's limit; the forecaster's own chance of this, stated with the estimate: 85%; the middle value does not contradict the limit.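

Neither new step, from compound 3 to compound 4 or from compound 2 to compound 4, can be read, because all four compounds share one limit: the limit of > 100000 nM in this assay, at which 4 of the 4 values shown sit.

The compounds shown leave open whether 3-fluorophenyl in place of 4-methoxyphenyl, or pentyl in place of phenyl, changes anything in this assay.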